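A few compounds are considered here, and "the series" means these few. Any claim that something is new, unique, unknown or untested is made for them only; others in the source may bear on it.

Measured in a functional assay on WM 266-4 cells (Homo sapiens) for antiproliferative activity, read by MTT assay, with a stated time of 24 h; on this read-out lower numbers stand for stronger inhibition of growth and higher numbers for weaker inhibition of growth:

- compound 1 `c1ccc(N2N=C(c3ccc4c(c3)OCCO4)CC2c2ccco2)cc1`: > 100000 nM
- compound 2 `Clc1ccc(C2CC(c3ccc4c(c3)OCCO4)=NN2c2ccccc2)cc1`: 38600 nM
- compound 3 `Brc1ccc(C2CC(c3ccc4c(c3)OCCO4)=NN2c2ccccc2)cc1`: 3010 nM

The entry for compound 1 is a limit of the assay and not a number. Compound 3 has the lowest number of the three, and both of its steps lie beyond the scatter: an at least 33-fold lower number from compound 1 to compound 3 (1.52 log units; beyond the scatter) and a 13-fold lower number from compound 2 to compound 3 (1.11 log units; beyond the scatter).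

Compound 4 `c1ccc(C2CC(c3ccc4c(c3)OCCO4)=NN2c2ccccc2)cc1` has not yet been measured in this assay. It carries hydrogen in place of bromo on an aromatic carbon, para to a large group: hydrogen in place of bromo on an aromatic carbon. Among the compounds with values here, no measured step makes exactly this change. The nearest guide is a 13-fold lower number from compound 2 to compound 3 (1.11 log units; beyond the scatter), a large step at the same place, which shows how much the choice of group there can matter. Also relevant is an at least 2.5-fold lower number from compound 1 to compound 2 (0.41 log units; beyond the scatter), which is smaller than an at least 33-fold lower number from compound 1 to compound 3 (1.52 log units; beyond the scatter). Losing the bromo is therefore expected to undo much of the advantage of compound 3, with a large move towards weaker inhibition of growth. The expected step is a 10-fold higher number from compound 3 to compound 4 (1.00 log units; beyond the scatter). For compound 4 the estimated value is 30000 nM, with an expected range from 8000 nM to 100000 nM.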

Compound 4, concentration for 50% growth inhibition: 22400 nM
Beside the measured number, compound 4's estimate is 1.3-fold (0.13 log units) above it; low and high end bracket the measured number.
By their numbers in this assay, from the lowest: compound 3; then compounds 4 and 2 (each within the scatter of the next). At a limit, above all of these: compound 1.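

In this assay, taking the bromo away gives a 7.4-fold higher number from compound 3 to compound 4 (0.87 log units; beyond the scatter), which shows directly that the advantage of compound 3 depends on the bromo at this place and does not come from the rest of the molecule. Chloro brings no such advantage, since a 1.7-fold lower number from compound 2 to compound 4 (0.24 log units; within the scatter) leaves the 4-chlorophenyl of compound 2 and the plain phenyl of compound 4 indistinguishable, so among hydrogen, chloro and bromo at this place, only bromo stands apart. The plain phenyl also shows that a halogen is not needed for the change from furan-2-yl to register, with an at least 4.4-fold lower number from compound 1 to compound 4 (0.64 log units; beyond the scatter), although this step is measured against an entry for compound 1 that is a limit of the assay and gives only a minimum size: the limit of > 100000 nM in this assay, at which 1 of the 4 values shown sits.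

The compounds shown leave open how iodo, fluoro, a methoxy group or an amine at this place would compare with bromo. They also leave open whether bromo would keep its advantage on a different core, as compounds 2, 3 and 4 all share the same one.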